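A few compounds are considered here, and "the series" means these few. Any claim that something is new, unique, unknown or untested is made for them only; others in the source may bear on it.

Measured so far:
compound 1 `Nc1sc(-c2ccc(Cl)cc2)c(-c2ccc(Cl)cc2)c1C(=O)N1CCNCC1` — 2710 nM
compound 2 `CN1CCN(C(=O)c2c(N)sc(-c3ccc(Cl)cc3)c2-c2ccc(Cl)cc2)CC1` — 13100 nM
compound 3 `CCN(CC)CCNC(=O)Nc1sc(-c2ccc(Cl)cc2)c(-c2ccc(Cl)cc2)c1C(=O)NC1CC1` — "not determined" (no result reported)

Three compounds share one core; two of them carry a number in a functional assay on PC-3 cells (Homo sapiens) for inhibition, read by sulforhodamine B assay, with a stated time of 72 h; a lower number here means a stronger inhibitor, a higher number a weaker inhibitor. In this assay compound 1 gives 2710 nM, and compound 2 gives 13100 nM, the higher of the two numbers. For compound 3, no result was reported. Within the data shown here, the one measured step, a 4.8-fold higher number from compound 1 to compound 2 (0.68 log units; beyond the scatter), came with the change of methyl in place of hydrogen on an amine nitrogen in a ring.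

Compound 4 `Nc1sc(-c2ccc(Cl)cc2)c(-c2ccc(Cl)cc2)c1C(=O)N1CCOCC1` has not been measured. It differs from compound 2 in one place: morpholin-4-yl in place of 4-methylpiperazin-1-yl on a carbonyl carbon.

Among the measured compounds shown here, no measured step covers this exchange of one ring for another, so only a loose guide exists. For the measured compounds named here, both compound 2 and compound 4 lack the hydrogen on the ring nitrogen that compound 1 carries, and the only measured step ran toward a higher number when that hydrogen was replaced. Compound 4 is therefore expected to stay near compound 2, with an estimated step of a 1.6-fold lower number from compound 2 to compound 4 (0.21 log units; within the scatter), not clearly beyond the scatter in either direction. The estimate for compound 4 is 8000 nM, within a range from 2500 nM to 25000 nM.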

Compound 4, half-maximal inhibitory concentration: 11700 nM
Estimate against measurement, compound 4: 1.5-fold (0.17 log units) below; the range from low to high includes it.
By their numbers in this assay, from the lowest: compound 1; then compounds 4 and 2 (each within the scatter of the next).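

In this assay, putting morpholin-4-yl in place of 4-methylpiperazin-1-yl on a carbonyl carbon gives a 1.1-fold lower number from compound 2 to compound 4 (0.05 log units; within the scatter), so these two rings cannot be told apart here. Putting morpholin-4-yl in place of piperazin-1-yl gives a 4.3-fold higher number from compound 1 to compound 4 (0.64 log units; beyond the scatter) and so, like the methyl change in a 4.8-fold higher number from compound 1 to compound 2 (0.68 log units; beyond the scatter), leads to a number clearly higher than that of compound 1. Two different changes to the piperazin-1-yl ring thus end in the same place, and compound 1 is the only one of the three measured compounds that keeps the hydrogen on the ring nitrogen, though no measurement here explains this.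

Going by these compounds, whether that hydrogen itself is what counts remains open. A piperidin-1-yl ring or an open-chain amine such as diethylamino on the carbonyl carbon would test the idea further.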